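This account rests on a few compounds, and the source may have more. Where it says the series, first, only, none or still open, it means among the compounds named here.

Measured compounds:
Compound 1 `Cc1ccc(CS(=O)(=O)/C(=C/c2ccc(N(C)C)cc2)C(=O)c2ccc(Cl)cc2)cc1` gives 50000 nM in a functional assay on DU-145 cells (Homo sapiens) for inhibition, read by trypan blue exclusion, with a stated time of 96 h; on this read-out lower numbers stand for stronger inhibition of growth and higher numbers for weaker inhibition of growth.
Compound 2 `Cc1ccc(CS(=O)(=O)/C(=C/c2sccc2C)C(=O)c2ccc(Cl)cc2)cc1` gives 25000 nM in this assay.
Compound 3 `CN(C)c1ccc(/C=C(/SCc2ccc(F)cc2)C(=O)c2ccc(Cl)cc2)cc1` gives 50000 nM in this assay.

The change from compound 1 to compound 2 is 3-methylthiophen-2-yl in place of 4-(dimethylamino)phenyl on a double-bonded chain carbon bound to a double-bonded chain carbon, and it made a 2.0-fold lower number from compound 1 to compound 2 (0.30 log units; within the scatter). Compound 3 and compound 1 stand level at the digits given, together the highest of the three values; how their cores differ is not broken down here. Compound 4 `Cc1ccsc1/C=C(/SCc1ccc(F)cc1)C(=O)c1ccc(Cl)cc1` carries the same change on the core of compound 3, namely (3-methylthiophen-2-yl in place of 4-(dimethylamino)phenyl on a double-bonded chain carbon bound to a double-bonded chain carbon), at the same place as in the first pair. Because a 2.0-fold lower number from compound 1 to compound 2 (0.30 log units; within the scatter) lay within the scatter, a step of similar size is expected in this assay, a 2.0-fold lower number from compound 3 to compound 4 (0.30 log units; within the scatter). Compound 4 is therefore estimated at 25000 nM, with a likely range from 12000 nM to 60000 nM.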

Compound 4, concentration for 50% growth inhibition: 50000 nM
Beside the measured number, compound 4's estimate is 2.0-fold (0.30 log units) below it; the range from low to high includes it.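

In this assay, putting 3-methylthiophen-2-yl in place of 4-(dimethylamino)phenyl on the core of compound 3 gave no change at the digits printed from compound 3 to compound 4 (within the scatter). Set beside the first pair, the two steps do not differ beyond what repeated measurement allows: the same change on two cores in this assay, a 2.0-fold lower number (0.30 log units; within the scatter) from compound 1 to compound 2 and no change at the digits printed (within the scatter) from compound 3 to compound 4, 2.0-fold (0.30 log units) apart, within the scatter of two such steps. The change therefore behaves alike on these two cores, but neither step shows that it alters growth inhibition, and two pairs establish no rule for the whole series.

The compounds shown leave open whether another group at this place, such as a pyridine ring or a phenyl ring bearing a carboxylic acid, would move the number beyond the scatter. They also leave open how the change behaves on any further core.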